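Swapping Fluoro for Chloro on the Fused Ring

The source may report more compounds than this note shows. Statements on the series, on what has been measured and on what is new or still open speak of the compounds shown alone.

The series rests on one shared core, and the three measured compounds are compared in a functional assay on MDA-MB-468 cells (Homo sapiens) for antiproliferative activity; a lower number here means a stronger inhibitor of growth, a higher number a weaker inhibitor of growth. Compound 1 `COc1ccc(-c2nc3cc(F)ccc3s2)cc1F` gives 640 nM in this assay. Compound 2 `COc1ccc(-c2nc3cc(F)ccc3s2)cc1Cl` gives 480 nM in this assay. Compound 3 `COc1ccc(-c2nc3cc(F)ccc3s2)cc1OC` is recorded in this assay at < 0.1 nM, and that figure is the limit of < 0.1 nM in this assay, at which 1 of the 3 values shown sits, not a number.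

Two changes separate these compounds. The first is chloro in place of fluoro on an aromatic carbon, which produced a 1.3-fold lower number from compound 1 to compound 2 (0.12 log units; within the scatter). The second is methoxy in place of fluoro on an aromatic carbon, which produced an at least 6400-fold lower number from compound 1 to compound 3 (3.80 log units; beyond the scatter); the same methoxy for chloro change produced an at least 4800-fold lower number from compound 2 to compound 3 (3.68 log units; beyond the scatter).

Compound 4 `COc1ccc(-c2nc3cc(Cl)ccc3s2)cc1OC` has not been measured. It differs from compound 3 by chloro in place of fluoro on an aromatic carbon. For the measured compounds named here, this is the same kind of change as the one from compound 1 to compound 2, but not the same: in compound 1 the halogen sits on a six-membered aromatic ring of carbon only, ortho to a methoxy group and meta to a large group, whereas in compound 3 it sits on a ring that is part of a fused or bridged system of two rings, meta to a fused ring and para to a fused ring.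

For compound 4 the expected step is a step that the limit leaves unreadable from compound 3 to compound 4, placed beside the measured 1.3-fold lower number from compound 1 to compound 2 (0.12 log units; within the scatter), on which this expectation rests. Compound 4 is therefore estimated at 0.08 nM in this assay, with a likely range from 0.02 nM to 0.5 nM, and it is expected that this assay may again report only a limit.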

Compound 4, concentration for 50% growth inhibition: 1000 nM
The estimate for compound 4 lay 13000-fold (4.10 log units) below the measured number; the whole stated range lies below it.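

In this assay, chloro in place of fluoro on an aromatic carbon gave an at least 10000-fold higher number from compound 3 to compound 4 (4.00 log units; beyond the scatter), so in this series a swap that left the number unchanged within the scatter on the core of compound 1 cannot be assumed to do the same on the core of compound 3. The two steps do not match, and what is shown does not reveal whether the gap comes from the place of the swap, now on a ring that is part of a fused or bridged system of two rings, or from the rest of the core, since the two pairs differ in both: the same change on two cores in this assay, a 1.3-fold lower number (0.12 log units; within the scatter) from compound 1 to compound 2 and an at least 10000-fold higher number (4.00 log units; beyond the scatter) from compound 3 to compound 4, at least 13000-fold (4.12 log units) apart, beyond the scatter of two such steps. Compound 3 stands at a limit and not at a number, so the step to compound 4 gives only a bound on the true size of the change: the limit of < 0.1 nM in this assay, at which 1 of the 4 values shown sits.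

The compounds shown leave open whether the large step belongs to chloro itself or would also follow from another group at that place, such as a hydrogen, a methyl group, an amine or a nitrile. They also leave open whether the methoxy group that separates compound 3 from compound 1 and compound 2 is needed for the swap to matter so much.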